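This account rests on a few compounds, and the source may have more. Where it says the series, first, only, none or still open, it means among the compounds named here.

Measured so far, in a functional assay on NCI/ADR-RES cells (Homo sapiens) for antiproliferative activity, read by MTT assay, with a stated time of 48 h; on this read-out higher numbers stand for weaker inhibition and lower numbers for stronger inhibition:

Compound 1 `C=C1[C@H](OC(C)=O)[C@@H](OC(C)=O)[C@@H](OC(C)=O)C(C)(C)/C=C/[C@H](C)[C@H](OC(=O)c2ccccc2)[C@@]2(O)C[C@@](C)(O)[C@H](OC(C)=O)[C@@H]2[C@H]1OCC(C)C`: > 100000 nM
Compound 2 `C=C1[C@H](OC(C)=O)[C@@H](OC(=O)c2cccc(C)c2)[C@@H](OC(C)=O)C(C)(C)/C=C/[C@H](C)[C@H](OC(=O)c2ccccc2)[C@@]2(O)C[C@@](C)(O)[C@H](OC(C)=O)[C@@H]2[C@H]1OCC(C)C`: > 100000 nM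
Compound 3 `C=C1[C@H](OC(C)=O)[C@@H](OC(C)=O)[C@@H](OC(C)=O)C(C)(C)/C=C/[C@H](C)[C@H]2O[C@]3(C)C[C@@]2(OC(=O)c2ccccc2)[C@H]([C@H]3OC(C)=O)[C@H]1OCC(C)C`: > 100000 nM

The value given for compound 1 is a limit of this assay and not a number. The value given for compound 2 is likewise a limit and not a number. The value given for compound 3 is a limit as well. In this assay the step from compound 1 to compound 2 is a step that the two limits leave unreadable from compound 1 to compound 2; the change behind it is 3-methylphenyl in place of methyl on a carbonyl carbon. Nothing about the size of that step can be read, a point that rests on (the limit of > 100000 nM in this assay, at which 3 of the 3 values shown sit).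

Compound 3 shares much with compound 1, but the difference between the two cores is not broken down here. Compound 4 `C=C1[C@H](OC(C)=O)[C@@H](OC(=O)c2cccc(C)c2)[C@@H](OC(C)=O)C(C)(C)/C=C/[C@H](C)[C@H]2O[C@]3(C)C[C@@]2(OC(=O)c2ccccc2)[C@H]([C@H]3OC(C)=O)[C@H]1OCC(C)C` is the not yet measured partner of compound 3, and it differs from compound 3 by 3-methylphenyl in place of methyl on a carbonyl carbon. The place of this change is described in the same words as for the pair of compound 1 and compound 2, so it is the same change made on the core of compound 3.

For compound 4 in this assay the expected step from its parent is a step that the limit leaves unreadable from compound 3 to compound 4, and this expectation rests on the fact that the same change left compound 1 and compound 2 both at the limit of > 100000 nM in this assay, at which 3 of the 3 values shown sit. The estimate for compound 4 in this assay is therefore 200000 nM, with the expected range from 100000 nM to 1000000 nM, and most likely the assay will again report only a limit.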

Compound 4, half-maximal inhibitory concentration: > 100000 nM
Compound 4: only a limit was reported; the forecaster's own chance of this, stated with the estimate: 90%; the middle value does not contradict the limit.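

No step can be read between compound 3 and compound 4, since each carries only a limit and not a number: the limit of > 100000 nM in this assay, at which 4 of the 4 values shown sit.

The compounds shown leave open how much activity any of them has in this assay, whether 3-methylphenyl in place of methyl makes any difference on either core, and what kind of structure would give a measurable value.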